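The source may report more compounds than this note shows. Statements on the series, on what has been measured and on what is new or still open speak of the compounds shown alone.

Compound 1, `O=C(NCc1ccccc1)c1cn(-c2ccccc2)nc1-c1cccnc1`: "nd(insoluble)" (no result reported) in a functional assay on Raji cells (Homo sapiens) for cytotoxicity, read by MTT assay, with a stated time of 48 h; a lower number here means a stronger inhibitor, a higher number a weaker inhibitor.
Compound 2, `COc1ccc(OC(=O)c2cn(-c3ccccc3)nc2-c2cccnc2)cc1`: > 100000 nM.
Compound 3, `O=C(NCc1ccccc1)c1cn(-c2ccccc2)nc1-c1ccncc1`: > 100000 nM.

Compound 3 stands at a limit of this assay rather than at a number. Two of the three entries sit at that same limit (the limit of > 100000 nM in this assay, at which 2 of the 3 values shown sit), and the third carries no result at all, so no measured step exists among these compounds, and compound 3 cannot be placed above or below either of the others.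

Compound 4, `COc1ccc(OC(=O)c2cn(-c3ccccc3)nc2-c2ccncc2)cc1`, differs from compound 3 in one place: 4-methoxyphenoxy in place of benzylamino on a carbonyl carbon. The same ester group is carried by compound 2, which also reaches only a limit in this assay. Among the compounds with values here, no measured pair shows what this change does on its own. The step expected from compound 3 to compound 4 in this assay is a number no higher from compound 3 to compound 4 (the limit leaves the size open), meaning none beyond the scatter. Compound 4 is therefore expected to give about 100000 nM, within 30000 nM to 300000 nM, and most probably to be reported once more only as a limit.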

Compound 4, half-maximal inhibitory concentration: > 100000 nM
Compound 4 ended at the assay's limit; the forecaster's own chance of this, stated with the estimate: 85%; the middle value lies on the limit itself.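

Compound 4 gives only a limit in this assay, as do compound 2 and compound 3, so neither step to compound 4 can be read: the limit of > 100000 nM in this assay, at which 3 of the 4 values shown sit.

The compounds shown leave open whether exchanging benzylamino for 4-methoxyphenoxy, or pyridin-3-yl for pyridin-4-yl, changes the value in this assay at all.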